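The compounds below may be only part of what the source reports. "The series", "measured", "known", "first", "only" and "open" are said of these compounds alone.

The measured compounds in a functional assay on MCF7 cells (Homo sapiens) for inhibition, read by sulforhodamine B assay, with a stated time of 48 h; on this read-out higher numbers stand for weaker inhibition of growth and lower numbers for stronger inhibition of growth:
compound 1 `Nc1cc(N)c2nc(-c3ccccc3)c(NCc3ccc(Cl)c(Cl)c3)nc2c1` gives 12300 nM
compound 2 `COc1ccc(CNc2nc3cc(N)cc(N)c3nc2-c2ccccc2)cc1OC` gives 25700 nM
compound 3 `COc1cc(CNc2nc3cc(N)cc(N)c3nc2-c2ccccc2)cc(OC)c1OC` gives 1550 nM

Compound 2 stands at the highest of the three numbers in this assay; its nearest neighbour is compound 1, separated by a 2.1-fold higher number from compound 1 to compound 2 (0.32 log units; beyond the scatter), and its furthest is compound 3, separated by a 17-fold lower number from compound 2 to compound 3 (1.22 log units; beyond the scatter). Compound 4 `COc1ccc(CNc2nc3cc(N)cc(N)c3nc2-c2ccccc2)cc1` is not yet measured. It differs from compound 2 by hydrogen in place of methoxy on an aromatic carbon, that is, 3,4-dimethoxyphenyl becomes 4-methoxyphenyl. Going by the values given here, only one measured step bears on this change: from compound 2 to compound 3 a methoxy is added and the result is a 17-fold lower number from compound 2 to compound 3 (1.22 log units; beyond the scatter), a large gain. Removing a methoxy is the reverse kind of change, although the methoxy removed is not the one that was added, so the expectation for compound 4 is a modest move in the opposite direction, a 1.4-fold higher number from compound 2 to compound 4 (0.13 log units; within the scatter), if anything beyond the scatter. Compound 4 is therefore expected to give about 35000 nM, within a range from 12000 nM to 100000 nM.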

Compound 4, concentration for 50% growth inhibition: 13200 nM
The estimate for compound 4 lay 2.7-fold (0.42 log units) above the measured number; measured number inside the range.
By their numbers in this assay, from the lowest: compound 3; then compounds 1, 4 and 2 (each within the scatter of the next, the first and the last beyond it).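

In this assay, taking away the methoxy that sits ortho to a methoxy group gives a 1.9-fold lower number from compound 2 to compound 4 (0.29 log units; within the scatter), so hydrogen and methoxy at this place cannot be told apart here, whereas adding a methoxy at another place on the same ring gave a 17-fold lower number from compound 2 to compound 3 (1.22 log units; beyond the scatter). The dichloro ring and the single methoxy ring also cannot be told apart, with a 1.1-fold higher number from compound 1 to compound 4 (0.03 log units; within the scatter), so 3,4-dichlorophenyl and 4-methoxyphenyl read alike on this core. No measurement shown here explains either result.

The compounds shown leave open whether a hydroxyl, an amine or an ethoxy at this place would give a number beyond the scatter of compound 4. They also leave open whether the large step to compound 3 depends on the methoxy groups already on the ring.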